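Opening the Five-Membered Ring of Compound 3

The source may report more compounds than this note shows. Statements on the series, on what has been measured and on what is new or still open speak of the compounds shown alone.

compound 1 `c1ccc(-c2ccc(NC3=NCCO3)cc2)cc1` gives 10600 nM
compound 2 `c1cc(NC2=NCCO2)cc(OC2CCCC2)c1` gives 62100 nM
compound 3 `c1ccc(COc2cccc(NC3=NCCO3)c2)cc1` gives 2600 nM

In a functional assay on MCF7 cells (Homo sapiens) for inhibition, read by sulforhodamine B assay, with a stated time of 48 h (a higher number here means a weaker inhibitor of growth, a lower number a stronger inhibitor of growth), compound 3 (2600 nM) has the lowest number of the three and is the strongest inhibitor of growth among them. Its distance from compound 1 (10600 nM) lies beyond the scatter, and so does its larger distance from compound 2 (62100 nM).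

The next structure is compound 4 `O=C(CCl)NC(=O)Nc1cccc(OCc2ccccc2)c1`, which has not yet been measured. It differs from compound 3 in one place: a group of 7 heavy atoms (3 carbon, 1 nitrogen, 2 oxygen, 1 chlorine; no ring) in place of a group of 5 heavy atoms (3 carbon, 1 nitrogen, 1 oxygen; one five-membered non-aromatic ring with 2 hetero atoms), on a nitrogen on an aromatic ring. The five-membered non-aromatic ring with 2 hetero atoms leaves, and a ((chloromethyl)carbonyl)carbamoyl group with no ring enters, on a nitrogen on an aromatic ring.

Going by the values given here, no measured pair shows what a change of this kind does, so the expectation is uncertain. It starts from compound 3 (2600 nM), the measured structure that shares the rest of compound 4. In this assay a small loss of strength is expected, with no step beyond the scatter. The expected change is a 1.5-fold higher number from compound 3 to compound 4 (0.19 log units; within the scatter) in size. For compound 4 the estimated value is 4000 nM, with an expected range from 1000 nM to 15000 nM.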

Compound 4, concentration for 50% growth inhibition: 6200 nM
Estimate against measurement, compound 4: 1.6-fold (0.19 log units) below, within the range that was stated.
By their numbers in this assay, from the lowest: compound 3; then compounds 4 and 1 (each within the scatter of the next); then compound 2.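

Going by these compounds alone, the exchange gives the first reading at this place, on a nitrogen on an aromatic ring: in this assay the opening of the ring gives a 2.4-fold higher number from compound 3 to compound 4 (0.38 log units; beyond the scatter) and this modest step lies beyond the scatter. The five-membered non-aromatic ring is thus not needed for growth inhibition in this series, as compound 4 carries the ((chloromethyl)carbonyl)carbamoyl group with no ring and still gives 6200 nM in this assay, although the open group does not hold the strength of the ring in compound 3. No measurement at hand accounts for this loss.

The step changes several things at once, since the ring leaves, a chlorine enters and the count of hydrogen-bond donors rises, so the compounds shown cannot divide the loss among these features. Still open, going by these compounds, is how the same position would respond to a plain acetylcarbamoyl group without the chlorine, or to a bromomethyl group in place of the chloromethyl, and whether the chlorine contributes to the remaining growth inhibition of compound 4 at all.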